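The source may hold more compounds than are shown below. What is called first, only, known or untested is meant among the compounds shown, and "the series" means these compounds.

Measured values in an assay on HEK293 cells for binding affinity to 5-hydroxytryptamine receptor 7 (Homo sapiens), read by radioligand binding; on this read-out lower numbers stand for stronger inhibition and higher numbers for weaker inhibition:
compound 1, `CN1CCCN(CCn2ccc3ccc(Br)cc32)CC1`, gives 31 nM;
compound 2, `Brc1ccc2ccn(CCN3CCCN4CCCCC4C3)c2c1`, gives 3 nM;
compound 3, `CN1CCCN(CCn2ccc3ccc(Cl)cc32)CC1`, gives 34 nM.

Compound 3 stands at the highest of the three numbers in this assay. Its nearest neighbour is compound 1, and the step between them, a 1.1-fold higher number from compound 1 to compound 3 (0.04 log units; within the scatter), lies within the scatter, so the two compounds cannot be ordered. Within the data shown here, compound 2 is the furthest away, at a clearly lower number, but it differs from compound 3 in the amine part rather than on the aromatic carbon, and no single-place step from compound 3 to compound 2 is available.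

Compound 4, `C=Cc1ccc2ccn(CCN3CCCN(C)CC3)c2c1`, is the next compound for this assay. The change from compound 3 is vinyl in place of chloro on an aromatic carbon. Among the measured compounds shown here, the only measured step at this position is the halogen swap from compound 1 to compound 3, which stayed within the scatter. For the measured compounds named here, no measured pair shows a vinyl in place of a halogen anywhere, so the expectation rests on a single, flat step and carries a wide range.

Compound 4 is therefore expected at 40 nM, with a range from 15 nM to 120 nM. The step this estimate implies, a 1.2-fold higher number from compound 3 to compound 4 (0.07 log units; within the scatter), is expected to remain within the scatter.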

Compound 4, inhibition constant: 109 nM
For compound 4 the middle estimate is 2.7-fold (0.44 log units) below the measured one; measured number inside the range.
By their numbers in this assay, from the lowest: compound 2; then compounds 1 and 3 (each within the scatter of the next); then compound 4.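

In this assay this position on the aromatic carbon, flat across the halogen swap with a 1.1-fold higher number from compound 1 to compound 3 (0.04 log units; within the scatter), does respond to a change of group: vinyl in place of chloro gives a 3.2-fold higher number from compound 3 to compound 4 (0.51 log units; beyond the scatter), and vinyl in place of bromo gives a 3.5-fold higher number from compound 1 to compound 4 (0.55 log units; beyond the scatter). Both steps are modest but lie beyond the scatter, so among these three compounds the position tolerates either halogen without a readable change, while the vinyl, with two carbon atoms and a double bond outside the aromatic rings, moves to a higher number and thus weaker inhibition. No evidence at hand bears on what lies behind this difference between the vinyl and the halogens.

The compounds shown leave open whether the shift follows the double bond or only the larger group, a question that ethyl, with the same two carbon atoms and no double bond, would help to settle, and whether methyl or methoxy at this position would stay with the halogens or with the vinyl. They also leave open whether the vinyl step holds to the same size on the amine part of compound 2.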